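Adding a Second Chloro Substituent on a Prostate Cell Growth Assay

The compounds below may be only part of what the source reports. "The series", "measured", "known", "first", "only" and "open" are said of these compounds alone.

Of the compounds shown here, three have been measured in a functional assay on PC-3 cells (Homo sapiens) for cytotoxicity, read by sulforhodamine B assay, with a stated time of 48 h; on this read-out higher numbers stand for weaker inhibition of growth and lower numbers for stronger inhibition of growth. Compound 1 `ClCc1ccc(Cn2cnc3c(Cl)ncnc32)cc1` gives 72400 nM. Compound 3 `ClCc1ccc(Cn2cnc3c(Cl)nc(Cl)nc32)cc1` gives 7240 nM; the step of a 10-fold lower number from compound 1 to compound 3 (1.00 log units; beyond the scatter) corresponds to the change (chloro in place of hydrogen on an aromatic carbon). Compound 2 `ClCc1ccccc1Cn1cnc2ncnc(Cl)c21` has the same atoms as compound 1 joined differently; the difference between the two cores is not broken down here. In this assay compound 2 gives 19100 nM, the second highest of the three numbers, standing nearer to compound 3 than to compound 1.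

Compound 4 `ClCc1ccccc1Cn1cnc2nc(Cl)nc(Cl)c21` has not yet been measured. It differs from compound 2 by chloro in place of hydrogen on an aromatic carbon, the same change as that made from compound 1 to compound 3. Since that change gave a 10-fold lower number from compound 1 to compound 3 (1.00 log units; beyond the scatter), compound 4 is expected to move from compound 2 by a step of a 7.6-fold lower number from compound 2 to compound 4 (0.88 log units; beyond the scatter). This expectation rests on a single precedent, and the range is therefore kept wide. The estimated value for compound 4 is 2500 nM, expected to lie between 800 nM and 8000 nM.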

Compound 4, concentration for total growth inhibition: 2570 nM
The estimate for compound 4 lay 1.0-fold (0.01 log units) below the measured number, and the stated range covers the measured number.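

In this assay a chloro group added between two ring nitrogen atoms gives a 7.4-fold lower number from compound 2 to compound 4 (0.87 log units; beyond the scatter), and the step keeps its size when carried from the core of compound 1 to the core of compound 2: the same change on two cores in this assay, a 10-fold lower number (1.00 log units; beyond the scatter) from compound 1 to compound 3 and a 7.4-fold lower number (0.87 log units; beyond the scatter) from compound 2 to compound 4, 1.3-fold (0.13 log units) apart, within the scatter of two such steps. Within these two cores, then, the change can be carried across, and a step seen on one core foretold the step on the other. Two cores are still only two cases, however: they set no rule for other cores, and they do not tell why the step holds.

The compounds shown leave open whether another group on that same carbon, such as an amine or a methoxy group, would give a step of similar size. Also open is what the chloromethyl group contributes, as every compound shown carries it, and how a carboxylic acid or a longer chain in its place would read.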